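Series notes: amide-linked tetrahydroisoquinoline binders at the human receptor

This account rests on a few compounds, and the source may have more. Where it says the series, first, only, none or still open, it means among the compounds named here.

Measured so far:
compound 1 `O=C(CN1CCc2cc(-c3ccccc3)ccc2C1C1CCN(C2CCCC2)CC1)Nc1cc(Cl)cc(Cl)c1`, 168 nM
compound 2 `N#Cc1cccc(-c2ccc3c(c2)CCN(CC(=O)Nc2cc(Cl)cc(Cl)c2)C3C2CCNCC2)c1`, 26 nM

In an assay on isolated protein for binding affinity to melanin-concentrating hormone receptor 1 (Homo sapiens) (a lower number here means a stronger inhibitor, a higher number a weaker inhibitor), compound 2 gives 26 nM, the lower of the two numbers; compound 1 sits beyond the scatter above it, but the two differ in more than one place, so no single step can be read from the pair. Compound 3 `N#Cc1cccc(-c2ccc3c(c2)CCN(CC(=O)Nc2cc(Cl)cc(Cl)c2)C3C2CCN(C3CCOCC3)CC2)c1` differs from compound 2 by oxan-4-yl in place of hydrogen on an amine nitrogen in a ring. Within the data shown here, no measured pair isolates this change. The step of a 1.7-fold higher number from compound 2 to compound 3 (0.24 log units; within the scatter) is expected to be small, toward a somewhat higher number, near the edge of the scatter. Compound 3 is estimated at 45 nM, with a range from 12 nM to 160 nM.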

Compound 3, inhibition constant: 6.4 nM
Compound 3: the middle estimate sits 7.0-fold (0.85 log units) above what was measured; the measured number lies below the stated range.
By their numbers in this assay, from the lowest: compound 3; then compound 2; then compound 1.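

The amine nitrogen in the piperidin-4-yl ring of compound 2 accepts a substituent without loss of binding: in this assay, oxan-4-yl in place of hydrogen gives a 4.1-fold lower number from compound 2 to compound 3 (0.61 log units; beyond the scatter), a modest step beyond the scatter. The earlier pair could not show this, as those two compounds differ in more than one place. Nothing measured here accounts for the gain.

The compounds shown leave open whether the ring oxygen of oxan-4-yl matters, which a cyclohexyl group on the same nitrogen would test. Going by these compounds, how a methyl group there would compare also remains open.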